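Three ortho substituents, then a methoxy

The source may hold more compounds than are shown below. What is called first, only, known or untested is meant among the compounds shown, and "the series" means these compounds.

Compound 1 `COc1ccccc1NC(=S)N1CCc2c(sc(NC(=O)c3ccccc3Cl)c2C(N)=O)C1`: 35200 nM
Compound 2 `COc1ccccc1NC(=S)N1CCc2c(sc(NC(=O)c3ccccc3I)c2C(N)=O)C1`: 41800 nM
Compound 3 `COc1ccccc1NC(=S)N1CCc2c(sc(NC(=O)c3ccccc3C(F)(F)F)c2C(N)=O)C1`: 34500 nM

In a functional assay on MKN-74 cells (Homo sapiens) for antiproliferative activity, with a stated time of 24 h (a higher number here means a weaker inhibitor, a lower number a stronger inhibitor), compound 1 gives 35200 nM, compound 2 gives 41800 nM and compound 3 gives 34500 nM. Compound 3 has the lowest of the three numbers, but the gaps are small: a 1.0-fold lower number from compound 1 to compound 3 (0.01 log units; within the scatter) and a 1.2-fold lower number from compound 2 to compound 3 (0.08 log units; within the scatter), and a 1.2-fold higher number from compound 1 to compound 2 (0.07 log units; within the scatter). Three different groups on the same aromatic carbon thus left this assay unchanged.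

Compound 4 `COc1ccccc1NC(=S)N1CCc2c(sc(NC(=O)c3ccccc3OC)c2C(N)=O)C1` differs from compound 3 by methoxy in place of trifluoromethyl on an aromatic carbon; put another way, the (2-(trifluoromethyl)phenyl)carbonyl becomes a (2-methoxyphenyl)carbonyl. For the measured compounds named here, no measured step involves a methoxy at this position, so the closest guidance is the set of three steps among chloro, iodo and trifluoromethyl, each within the scatter. On that basis the step from compound 3 to compound 4 is expected to be a 1.0-fold higher number from compound 3 to compound 4 (0.02 log units; within the scatter), that is, nothing beyond the scatter. For compound 4 the estimate in this assay is 36000 nM, with a range from 17000 nM to 80000 nM.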

Compound 4, half-maximal inhibitory concentration: > 50000 nM
Compound 4 gave a limit, no number (the forecaster's own chance of this, stated with the estimate: 10%); at least 1.3-fold (0.14 log units) between middle value and limit.
By their numbers in this assay, from the lowest: compounds 3, 1 and 2 (each within the scatter of the next). At a limit, above all of these: compound 4.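

In this assay compound 4 is the only one of the four that reaches a limit rather than a number: the limit of > 50000 nM in this assay, at which 1 of the 4 values shown sits.

Measured against the three compounds with numbers, the replacement by methoxy gives an at least 1.4-fold higher number from compound 3 to compound 4 (0.16 log units; that floor lies within the scatter), an at least 1.4-fold higher number from compound 1 to compound 4 (0.15 log units; that floor lies within the scatter) and an at least 1.1-fold higher number from compound 2 to compound 4 (0.07 log units; that floor lies within the scatter). Each of these floors lies within the scatter, so the change is not shown to be a real loss, yet the flat picture seen with chloro, iodo and trifluoromethyl at this aromatic carbon cannot be extended to methoxy.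

From the compounds shown here alone, how far compound 4 lies past its limit stays open, and with it whether methoxy differs from the other three groups at all. Also open, going by these compounds, is whether an amine, a hydroxyl or a carboxylic acid on this carbon would give a number like those of compounds 1 to 3 or another limit.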